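The source may report more compounds than this note shows. Statements on the series, on what has been measured and on what is new or still open speak of the compounds shown alone.

In an ADME assay on microsomes from liver (Homo sapiens) for metabolic stability, tested at 2.5 uM (a higher number here means faster removal of the compound, a lower number slower removal), compound 1, `Fc1ccc(-c2ccc(Cn3nnc4ccccc43)cc2)c(Cl)c1`, gives 0.7 mL/min/g. Compound 2, `Clc1ccc(-c2ccc(Cn3nnc4ccccc43)cc2)c(Cl)c1`, is its partner in a single change, described as chloro in place of fluoro on an aromatic carbon, and in this assay compound 2 gives 0.6 mL/min/g. The step this change made is a 1.2-fold lower number from compound 1 to compound 2 (0.07 log units; within the scatter), so the two numbers show no separation that the assay can resolve.

Compound 3, `Fc1ccc(Cn2nnc3c(Br)cccc32)cc1`, stands on a different core; how that core differs from the core of compound 1 is not broken down here. In this assay compound 3 gives 1.2 mL/min/g. Its values against compound 1 and compound 2 fall within the usual scatter of this kind of measurement, so nothing separates them.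

Compound 4, `Clc1ccc(Cn2nnc3c(Br)cccc32)cc1`, has not been measured in this assay. It differs from compound 3 by chloro in place of fluoro on an aromatic carbon. Among the compounds with values here, this is the same kind of change as the one from compound 1 to compound 2, though the surroundings are not identical: in compound 1 the place is also meta to a chloro group, whereas in compound 3 it is described only as para to a large group.

Compound 4 is expected to show a step of about a 1.2-fold lower number from compound 3 to compound 4 (0.08 log units; within the scatter), because the earlier instance of this change gave a 1.2-fold lower number from compound 1 to compound 2 (0.07 log units; within the scatter), a step within the scatter. On that basis the value of compound 4 in this assay is estimated at 1 mL/min/g, with a likely range from 0.5 mL/min/g to 2 mL/min/g.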

Compound 4, intrinsic clearance in a liver preparation (reported as CLH), per the amount of preparation that the assay uses: 0.6 mL/min/g
Compound 4: middle estimate off by 1.7-fold (0.22 log units), on the high side; low and high end bracket the measured number.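

In this assay, chloro in place of fluoro on an aromatic carbon, para to a large group, gives a 2.0-fold lower number from compound 3 to compound 4 (0.30 log units; within the scatter), so on the core of compound 3 the exchange produces no separation that the measurement can resolve, as was the case on the core of compound 1. Set side by side, the two steps cannot be told apart: the same change on two cores in this assay, a 1.2-fold lower number (0.07 log units; within the scatter) from compound 1 to compound 2 and a 2.0-fold lower number (0.30 log units; within the scatter) from compound 3 to compound 4, 1.7-fold (0.23 log units) apart, within the scatter of two such steps Within this series, the exchange therefore looks transferable between these two cores in the limited sense that neither step leaves the scatter, but this rests on only two pairs, whose surroundings are not identical, and it shows neither a real shift in the read-out on either core nor that the same result would hold on a third core.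

The compounds shown place only fluoro and chloro at this position, so it remains open whether a methyl group, a methoxy group, a nitrile or an amine there would give a step beyond the scatter. As far as these compounds go, it is also open whether the exchange would behave the same way on a version of the core of compound 3 carrying a hydrogen or a methyl group instead of the bromo substituent.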